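Quinolin-8-yl Replaces Methoxypyridinyl on the Amide Carbon

This account rests on a few compounds, and the source may have more. Where it says the series, first, only, none or still open, it means among the compounds named here.

Among the measured compounds shown here, compound 2 `COc1ccncc1C(=O)NCCC1CCN(S(=O)(=O)NC(=O)NC[C@@H]2C[C@@H]3C=C[C@@H]2C3)CC1` has the lowest of the two numbers measured so far in a functional assay on the whole organism (blood) with Rattus norvegicus as the target, with stated times of 24 h and 1 h, at a dose of 5 mg/kg by the intraperitoneal route; on this read-out lower numbers stand for a weaker effect and higher numbers for a stronger effect at the one dose given; in this assay compound 2 gives 14%. For the measured compounds named here, its only measured neighbour is compound 1 `O=C(NC[C@@H]1C[C@@H]2C=C[C@@H]1C2)NS(=O)(=O)N1CCC(CCNC(=O)C(F)(F)F)CC1`, which in this assay gives 22%. Going by the values given here, the single step between them, a number 8 percentage points lower from compound 1 to compound 2 (within the scatter), stays within the scatter, so the two values cannot be told apart.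

Compound 3 `O=C(NC[C@@H]1C[C@@H]2C=C[C@@H]1C2)NS(=O)(=O)N1CCC(CCNC(=O)c2cccc3cccnc23)CC1` changes the same place again: quinolin-8-yl in place of 4-methoxypyridin-3-yl on a carbonyl carbon. Among the compounds with values here, the only step that bears on this change is the one from compound 1 to compound 2, which swapped the group on the carbonyl carbon and produced no difference beyond the scatter. On that basis a step of similar size, a number 3 percentage points higher from compound 2 to compound 3 (within the scatter), is expected, with no clear direction. Compound 3 is therefore estimated to give 17% in this assay, within a range from 4% to 32%.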

Compound 3, a percentage reported as activity, at one dose (the size of the read-out at that dose, not a potency): 34%
For compound 3 the middle estimate is 17 percentage points below the measured one, and the stated range ends below it.
By their numbers in this assay, from the lowest: compounds 2 and 1 (each within the scatter of the next); then compound 3.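

In this assay the group on the carbonyl carbon now makes a readable difference: the step is a number 20 percentage points higher from compound 2 to compound 3 (beyond the scatter) and the earlier swap at this place gave nothing beyond the scatter. Compound 3 also stands clear of the trifluoromethyl compound, with a number 12 percentage points higher from compound 1 to compound 3 (beyond the scatter) and so it alone has a number apart from both others. Nothing available explains why the quinolin-8-yl group gives this higher number.

Among the compounds shown here, only three groups have been compared at this place, and they differ in several ways at once. As far as these compounds go, it remains open whether a phenyl group, a naphthalen-1-yl group with carbon-only rings, or an amine on the same carbonyl carbon would give a number like that of compound 3.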